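A few compounds are considered here, and "the series" means these few. Any claim that something is new, unique, unknown or untested is made for them only; others in the source may bear on it.

Measured compounds:
Compound 1 `O=S(=O)(Nc1cc(-c2cnc3[nH]cc(-c4ccncc4)c3c2)cnc1Cl)c1ccccc1F`.
Compound 2 `O=S(=O)(Nc1cc(-c2cnc3[nH]nc(-c4ccccc4)c3c2)cnc1Cl)c1ccccc1`.

In a functional assay on NCI-H460 cells (Homo sapiens) for inhibition, read by sulforhodamine B assay, with a stated time of 72 h (a lower number here means a stronger inhibitor of growth, a higher number a weaker inhibitor of growth), compound 1 gives > 10000 nM, which is a limit of the measurement and not a number. In this assay compound 2 gives 8650 nM. Compound 1 thus stands at the limit of > 10000 nM in this assay, at which 1 of the 2 values shown sits, with no number of its own. Compound 3 `O=S(=O)(Nc1cc(-c2cnc3[nH]cc(-c4ccncc4)c3c2)cnc1Cl)c1ccc(F)cc1` is not yet measured; it differs from compound 1 by 4-fluorophenyl in place of 2-fluorophenyl on a sulfonyl sulfur. Within the data shown here, no measured pair shows this change on its own. The step of a number no higher from compound 1 to compound 3 (the limit leaves the size open) is expected to be none beyond the scatter, because compound 1 sits at the limit of > 10000 nM in this assay, at which 1 of the 2 values shown sits. Compound 3 is estimated at 10000 nM, with a range from 3000 nM to 30000 nM.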

Compound 3, concentration for 50% growth inhibition: 6190 nM
For compound 3 the middle estimate is 1.6-fold (0.21 log units) above the measured one; low and high end bracket the measured number.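

In this assay, 4-fluorophenyl in place of 2-fluorophenyl on a sulfonyl sulfur gives an at least 1.6-fold lower number from compound 1 to compound 3 (0.20 log units; that floor lies within the scatter). The core of compound 1 thus gets a number of its own from compound 3, which gives 6190 nM. The true size of the step stays open because the value of compound 1 is a limit and not a number: the limit of > 10000 nM in this assay, at which 1 of the 3 values shown sits.

Whether this step would exceed the scatter remains unresolved. Also open, going by these compounds, is what an amine or a short alkyl chain in place of the fluorophenyl on a sulfonyl sulfur would do to growth inhibition.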